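Mirror-Image Change at a Saturated Chain Carbon

The source may report more compounds than this note shows. Statements on the series, on what has been measured and on what is new or still open speak of the compounds shown alone.

Compound 1, `CC(C)n1nc(N2CC(C(C)(C)O)C2)c2cnc(Nc3ccnc(-c4cnn(S(=O)(=O)C5CC5)c4)n3)cc21`: in a physicochemical assay for solubility, in phosphate buffer, measured as kinetic solubility, with a stated time of 24 h, at pH 7.4, tested at 100 uM (a higher number here means a more soluble compound, a lower number a less soluble compound), compound 1 gives < 1000 nM, which is a limit of the assay and not a number.
Compound 2, `CC[C@@H](C)n1nc(N2CC(C(C)(C)O)C2)c2cnc(Nc3ccnc(-c4cnn(S(=O)(=O)C5CC5)c4)n3)cc21`: in this assay compound 2 gives 2000 nM.

For the measured compounds named here, compound 2 stands as the only compound with a numerical value in this assay. The other value shown belongs to compound 1 and is a limit, as the limit of < 1000 nM in this assay, at which 1 of the 2 values shown sits, records. Going by the values given here, the single measured step, an at least 2.0-fold higher number from compound 1 to compound 2 (0.30 log units; that floor lies within the scatter), starts from that limit and therefore gives only a floor for the change.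

Compound 3, `CC[C@H](C)n1nc(N2CC(C(C)(C)O)C2)c2cnc(Nc3ccnc(-c4cnn(S(=O)(=O)C5CC5)c4)n3)cc21`, is the compound still to be measured. It differs from compound 2 as follows: the two compounds have the same atoms and bonds and differ only in configuration as drawn: 1 of 1 stereo elements differ; a stereocentre at a saturated chain carbon is drawn R in compound 2 and S in compound 3. Among the compounds with values here, no measured step concerns a change of configuration alone; the step from compound 1 to compound 2 adds a methyl group and does not bear on this change. With nothing in the measured steps pointing either way, the expectation for compound 3 in this assay is no step beyond the scatter, that is no change at the digits printed from compound 2 to compound 3 (within the scatter). Compound 3 is therefore estimated at 2000 nM, within a range from 1000 nM to 4000 nM.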

Compound 3, solubility: 2000 nM
Compound 3: the middle estimate sits on the measured number at the digits printed, and the stated range covers the measured number.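

For the compounds shown here, with the stereocentre at the saturated chain carbon drawn R and then S, this assay gives no change at the digits printed from compound 2 to compound 3 (within the scatter) and so shows for the first time how this position responds to configuration on its own, in a comparison that carries no other difference: the fact that compounds 2 and 3 differ only in the configuration as drawn.

The change of methyl in place of hydrogen on the saturated chain carbon can now be read for the S form as well as the R form, with an at least 2.0-fold higher number from compound 1 to compound 3 (0.30 log units; that floor lies within the scatter) as its result, and this again gives no more than a floor. Going by these compounds, compound 1 remains a limit and not a number, so the true size of both methyl steps stays unknown: the limit of < 1000 nM in this assay, at which 1 of the 3 values shown sits.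

The compounds shown leave open whether configuration at this carbon stays without a mark in this assay when the chain is longer or carries a hydroxyl group or an amine. They also leave open whether the two mirror-image forms stay this close in any read-out other than this one.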